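Quinone series: ethoxy to trifluoromethyl on the arylamine

A few compounds are considered here, and "the series" means these few. Any claim that something is new, unique, unknown or untested is made for them only; others in the source may bear on it.

Measured compounds in a functional assay on ECa-109 cells for inhibition, with ECa-109 cell line (Homo sapiens) as the target, read by sulforhodamine B assay; on this read-out higher numbers stand for weaker inhibition and lower numbers for stronger inhibition:
compound 1 `CCOc1ccc(NC2=CC(=O)c3c(nc4n3[C@H]3OC[C@@H](O)[C@H]3OC4)C2=O)cc1`, > 4000 nM
compound 2 `O=C1C=C(Nc2ccc(C(F)(F)F)cc2)C(=O)c2c1nc1n2[C@H]2OC[C@@H](O)[C@H]2OC1`, 5500 nM
compound 3 `O=C1C=C(NC2CCCCC2)C(=O)c2c1nc1n2[C@H]2OC[C@@H](O)[C@H]2OC1`, > 16000 nM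

Compound 1 stands only at a limit of this assay , not at a number; the value > 4000 nM marks that limit (the limit of > 4000 nM in this assay, at which 1 of the 3 values shown sits). Compound 3 also stands at a limit, (the limit of > 16000 nM in this assay, at which 1 of the 3 values shown sits). Within the data shown here, the one measured step is an at least 2.9-fold higher number from compound 2 to compound 3 (0.46 log units; beyond the scatter), a weakening beyond the scatter. Among the measured compounds shown here, compound 2 is the only compound with a number in this assay .

The unmeasured compound 4 `O=C1C(Nc2ccc(C(F)(F)F)cc2)=CC(=O)c2c1nc1n2[C@H]2OC[C@@H](O)[C@H]2OC1` differs from compound 1 by trifluoromethyl in place of ethoxy on an aromatic carbon. For the measured compounds named here, no measured step covers this change directly; the shared core and the 4-(trifluoromethyl)phenyl group on the amine nitrogen are those of compound 2, so the number given by compound 2 , 5500 nM, is the closest guide. Compound 4 is therefore expected to give about 6000 nM in this assay , estimated within 2500 nM to 15000 nM. The step from compound 1 that this estimate implies, a step that the limit leaves unreadable from compound 1 to compound 4, is expected to be small or none beyond the scatter, since compound 1 offers only a limit.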

Compound 4, half-maximal inhibitory concentration: 2250 nM
Beside the measured number, compound 4's estimate is 2.7-fold (0.43 log units) above it, and the stated range ends above it.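

In this assay, trifluoromethyl in place of ethoxy on an aromatic carbon gives an at least 1.7-fold lower number from compound 1 to compound 4 (0.24 log units; that floor lies within the scatter). That floor is all this pair yields, because compound 1 stands at a limit and not at a number: the limit of > 4000 nM in this assay, at which 1 of the 4 values shown sits.

Compound 2 gives 5500 nM and compound 4 gives 2250 nM; these are the only two numbers in the series shown, and both compounds carry the 4-(trifluoromethyl)phenyl group.

On these data alone, the true size of the change from ethoxy to trifluoromethyl stays open while compound 1 has only a limit. Also open, as far as these compounds go, is how a nitrile, a carboxylic acid or a longer alkoxy chain on this aromatic carbon would read in this assay.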